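Half-life of a triazole for a phenyl on a piperidine amide

This account rests on a few compounds, and the source may have more. Where it says the series, first, only, none or still open, it means among the compounds named here.

Measured compounds:
- compound 1, `O=C(c1ccccc1)N1CCC(C(=O)N2N=CCC2c2ccccc2)CC1`: 1.72 h
- compound 2, `O=C(C1CCC1)N1N=CCC1c1ccccc1`: 1.38 h
- compound 3, `N#Cc1nccc(N2CCC(C(=O)N3N=CC[C@H]3c3cc(F)cc(F)c3)CC2)n1`: 2.1 h

The account follows compound 1 to the unmeasured compound 4, `O=C(c1c[nH]nn1)N1CCC(C(=O)N2N=CCC2c2ccccc2)CC1`. In an ADME assay on microsomes (Homo sapiens) for metabolic stability (on this read-out lower numbers stand for a shorter-lived compound and higher numbers for a longer-lived compound), compound 1 gives 1.72 h. Its closest neighbour among the three numbers is compound 3, and the gap to compound 2 on the other side is also within the usual scatter, so all three measured compounds sit together on this read-out and none can be called the longest- or shortest-lived.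

Compound 4 differs from compound 1 in one place: 1H-1,2,3-triazol-4-yl in place of phenyl on a carbonyl carbon. Within the data shown here, no pair of measured compounds shows this change, so no measured step tells what to expect of it. The three numbers seen so far lie close together despite quite different groups on the carbonyl, which gives no reason to expect a large movement. The step of a 1.2-fold higher number from compound 1 to compound 4 (0.07 log units; within the scatter) is therefore expected to be small, if any, and to stay within the scatter. Compound 4 is estimated at 2 h, with a range from 1 h to 4 h.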

Compound 4, half-life: > 2.75 h
Compound 4 gave a limit, no number; the forecaster's own chance of this, stated with the estimate: 5%; middle value at least 1.3-fold (0.13 log units) from the limit.
By their numbers in this assay, from the lowest: compounds 2, 1 and 3 (each within the scatter of the next). At a limit, above all of these: compound 4.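

In this assay, among these compounds, replacing phenyl with 1H-1,2,3-triazol-4-yl on a carbonyl carbon gives the first measured step at this position: an at least 1.5-fold higher number from compound 1 to compound 4 (0.20 log units; that floor lies within the scatter). The value of compound 4 is a limit and not a number, so this step is only a floor: the limit of > 2.75 h in this assay, at which 1 of the 4 values shown sits. The earlier compounds shown here could not show that a five-membered aromatic ring with 3 hetero atoms and 1 hydrogen-bond donor can take the place of phenyl here without a shorter-lived result on this read-out.

From the compounds shown here alone, the true size of the step remains open, including whether it lies beyond the scatter. Going by these compounds, it is also open whether a pyridine ring or a methylated triazole on the same carbonyl carbon would read like phenyl or like 1H-1,2,3-triazol-4-yl.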